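Two Hydroxy-to-Amino Swaps Against One Assay Limit

The compounds below may be only part of what the source reports. "The series", "measured", "known", "first", "only" and "open" are said of these compounds alone.

Compound 1 `N#C[C@]1(O)[C@H](O)[C@@H](CO)O[C@@H](n2ccc(O)nc2=O)[C@@H]1O` opens the set. In a functional assay on CCRF-CEM cells (Homo sapiens) (a higher number here means a weaker inhibitor, a lower number a stronger inhibitor), compound 1 gives only a limit, > 500000 nM. Compound 2 `N#C[C@]1(O)[C@H](O)[C@@H](CO)O[C@@H](n2ccc(N)nc2=O)[C@@H]1O` is reached from compound 1 by amino in place of hydroxy on an aromatic carbon. In this assay compound 2 likewise gives only a limit, > 500000 nM. The step that the two limits leave unreadable from compound 1 to compound 2 can therefore not be sized; all the pair shows is the limit of > 500000 nM in this assay, at which 3 of the 3 values shown sit.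

Compound 3 `N#C[C@H]1[C@@H](O)[C@H](n2ccc(O)nc2=O)O[C@H](CO)[C@H]1O` is built on a different core, and how its core differs from the core of compound 1 is not broken down here. In this assay compound 3 gives only a limit, > 500000 nM. Compound 4 `N#C[C@H]1[C@@H](O)[C@H](n2ccc(N)nc2=O)O[C@H](CO)[C@H]1O` stands to compound 3 as compound 2 stands to compound 1: it is reached by amino in place of hydroxy on an aromatic carbon, the same change at the same place.

Set beside the unreadable step from compound 1 to compound 2, the step of a number no higher from compound 3 to compound 4 (the limit leaves the size open) is expected to stay flat as well. This expectation rests on (the limit of > 500000 nM in this assay, at which 3 of the 3 values shown sit), the limit at which compound 1, compound 2 and compound 3 all sit, and on the fact that the change of core from compound 1 to compound 3 left compound 3 at that same limit.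

For compound 4 the half-maximal inhibitory concentration is accordingly estimated at 500000 nM, within 150000 nM to 1500000 nM, and it is expected that this assay will once more report only a limit.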

Compound 4, half-maximal inhibitory concentration: > 750000 nM
Compound 4 was reported as a limit (the forecaster's own chance of this, stated with the estimate: 85%); middle value at least 1.5-fold (0.17 log units) from the limit.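

In this assay compound 4 gives only a limit, > 750000 nM. Compound 3 also gives only a limit, > 500000 nM, so the step between these two compounds cannot be read, just as the step from compound 1 to compound 2 cannot. The compounds shown leave open whether amino in place of hydroxy on an aromatic carbon alters the half-maximal inhibitory concentration on either core: every value shown is a limit.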